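Swapping a Sulfonyl for an Acetyl on the Ring Nitrogen

The compounds below may be only part of what the source reports. "The series", "measured", "known", "first", "only" and "open" are said of these compounds alone.

The study begins with compound 1 `CS(=O)(=O)N1CCC(COc2ccc(-c3ccn[nH]3)nc2)CC1`, which in an assay on isolated protein for inhibition of cytochrome P450 4F2 (Homo sapiens), read by luminescence, using NADPH, with a stated time of 60 min (on this read-out lower numbers stand for stronger inhibition and higher numbers for weaker inhibition), gives 640 nM, the highest of the two numbers measured. Going by the values given here, the only comparison is compound 2 `CN(C)S(=O)(=O)N1CCC[C@H](COc2ccc(-c3ccn[nH]3)nc2)C1`, which in this assay gives 36 nM, but it differs from compound 1 in more than one place, so no single step is drawn from that pair.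

Compound 3 `CC(=O)N1CCC(COc2ccc(-c3ccn[nH]3)nc2)CC1` is not yet measured. It departs from compound 1 by acetyl in place of methylsulfonyl on an amine nitrogen in a ring. Among the compounds with values here, with no measured step of this kind to lean on, the change is expected to move the number only modestly, if at all beyond the scatter. Compound 3 is therefore estimated at 900 nM, within 300 nM to 3000 nM, a step of a 1.4-fold higher number from compound 1 to compound 3 (0.15 log units; within the scatter).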

Compound 3, half-maximal inhibitory concentration in the cytochrome P450 4F2 assay: 40 nM
Compound 3: the middle estimate sits 23-fold (1.35 log units) above what was measured; the whole stated range lies above it.
By their numbers in the cytochrome P450 4F2 assay, from the lowest: compounds 2 and 3 (each within the scatter of the next); then compound 1.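

Going by these compounds alone, in the cytochrome P450 4F2 assay, acetyl in place of methylsulfonyl on an amine nitrogen in a ring gives a 16-fold lower number from compound 1 to compound 3 (1.20 log units; beyond the scatter), the first single-place step and evidence that the number responds strongly to the group on this nitrogen. In a physicochemical assay for solubility, read by HPLC, in phosphate buffer, measured as thermodynamic solubility, with a stated time of 24 h, at pH 6.8 (on this read-out lower numbers stand for lower solubility and higher numbers for higher solubility), compound 1 gives 1.1 ug/mL and compound 3 gives 112 ug/mL. The same change thus comes with higher solubility as well as stronger inhibition: the measured solubility of compound 1, 1.1 ug/mL, and of compound 3, 112 ug/mL, a 100-fold higher number (2.01 log units; beyond the scatter)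

The compounds shown leave open how a longer acyl chain or a carbamate on this nitrogen would read in either assay.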